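This account rests on a few compounds, and the source may have more. Where it says the series, first, only, none or still open, it means among the compounds named here.

Measured so far in an assay on L cells for inhibition of Protein-serine O-palmitoleoyltransferase porcupine (Mus musculus), read by reporter gene assay, with a stated time of 24 h; on this read-out lower numbers stand for an effect already at smaller amounts and higher numbers for an effect only at larger amounts of compound:
compound 1 `O=C(CSc1nc2c(c(=O)n1-c1ccccc1)SCC2)Nc1nc2ccc(Cl)cc2s1` gives 40 nM;
compound 2 `COc1ccccc1-n1c(SCC(=O)Nc2nc3ccc(Cl)cc3s2)nc2c(c1=O)SCC2` gives 50 nM;
compound 3 `COc1ccc2nc(NC(=O)CSc3nc4c(c(=O)n3-c3ccccc3)SCC4)sc2c1` gives 40 nM.

Compound 4 `COc1ccc2nc(NC(=O)CSc3nc4c(c(=O)n3-c3ccccc3OC)SCC4)sc2c1` has not yet been measured in this assay. It differs from compound 3 by methoxy in place of hydrogen on an aromatic carbon. The same change turns compound 1 into compound 2, namely (methoxy in place of hydrogen on an aromatic carbon), and there the step was a 1.3-fold higher number from compound 1 to compound 2 (0.10 log units; within the scatter). The two cores on which this change is made differ by methoxy in place of chloro on an aromatic carbon, and that step was no change at the digits printed from compound 1 to compound 3 (within the scatter), so both starting points sit at the same level. Compound 4 is therefore expected to move from compound 3 by about as much as the earlier step, a 1.3-fold higher number from compound 3 to compound 4 (0.10 log units; within the scatter), because the earlier step of a 1.3-fold higher number from compound 1 to compound 2 (0.10 log units; within the scatter) stayed within the scatter. For compound 4 the estimate in this assay is 50 nM, with a likely range from 25 nM to 100 nM.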

Compound 4, half-maximal effective concentration: 50 nM
Compound 4: middle estimate and measured number agree at the digits printed; low and high end bracket the measured number.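

In this assay, methoxy in place of hydrogen, which turns phenyl into 2-methoxyphenyl, gives a 1.3-fold higher number from compound 3 to compound 4 (0.10 log units; within the scatter), and this matches the same change on the other core: the same change on two cores in this assay, a 1.3-fold higher number (0.10 log units; within the scatter) from compound 1 to compound 2 and a 1.3-fold higher number (0.10 log units; within the scatter) from compound 3 to compound 4, 1.0-fold (0.00 log units) apart, within the scatter of two such steps.

Methoxy in place of chloro, made on the core of compound 2, gives no change at the digits printed from compound 2 to compound 4 (within the scatter), which also matches the earlier step: the same change on two cores in this assay, no change at the digits printed (within the scatter) from compound 1 to compound 3 and no change at the digits printed (within the scatter) from compound 2 to compound 4, 1.0-fold (0.00 log units) apart, within the scatter of two such steps.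

Across these four compounds, each change therefore reads the same on both cores, but every step stays within the scatter, so this shows only that two small steps carried over, not that a step of real size would.

On these data alone, it remains open whether an amine or a carboxylic acid in place of the methoxy would shift the number beyond the scatter. Also open, as far as these compounds go, is whether a longer chain, such as ethoxy, would do so.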